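Swapping methyl for fluoro on a carboxy compound

The source may hold more compounds than are shown below. What is called first, only, known or untested is meant among the compounds shown, and "the series" means these compounds.

Measured in a functional assay on A-375 cells (Homo sapiens) for antiproliferative activity, read by MTT assay, with a stated time of 24 h; on this read-out higher numbers stand for weaker inhibition and lower numbers for stronger inhibition:
Compound 1 `Cc1ccc2nc(C(=O)Nc3c(F)cc(-c4cccc(F)c4)cc3F)c(C)c(O)c2c1`: 90500 nM
Compound 2 `Cc1ccc2nc(C(=O)Nc3c(F)cc(-c4cccc(F)c4)cc3F)c(C)c(C(=O)O)c2c1`: 26000 nM

Of the two compounds measured in this assay, compound 2 has the lower number, at 26000 nM. Compound 3 `Cc1c(C(=O)Nc2c(F)cc(-c3cccc(F)c3)cc2F)nc2ccc(F)cc2c1C(=O)O` keeps the carboxy group of compound 2 but has fluoro in place of methyl on an aromatic carbon. For the measured compounds named here, only one measured step exists: a 3.5-fold lower number from compound 1 to compound 2 (0.54 log units; beyond the scatter), with carboxy in place of hydroxy on an aromatic carbon. Going by the values given here, that modest step lies at a different place in the structure, so it bears on this change only indirectly, and no measured step tests fluoro in place of methyl. A small step within the scatter is therefore expected, and the data favour no clear direction. The estimated step is a 1.1-fold lower number from compound 2 to compound 3 (0.03 log units; within the scatter). Compound 3 is expected at 24000 nM, with an estimated range of 9000 nM to 60000 nM.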

Compound 3, half-maximal inhibitory concentration: 81900 nM
Beside the measured number, compound 3's estimate is 3.4-fold (0.53 log units) below it, and the stated range ends below it.
By their numbers in this assay, from the lowest: compound 2; then compounds 3 and 1 (each within the scatter of the next).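

Fluoro in place of methyl on this aromatic carbon of the carboxy compound gives a 3.2-fold higher number from compound 2 to compound 3 (0.50 log units; beyond the scatter) in this assay and so moves the read-out toward weaker inhibition. The earlier compounds shown here differed only at the hydroxy or carboxy place, so they could not show that this other place also responds to change. Here the exchange of one heavy atom for another, with no change in the counted hydrogen-bond donors, hydrogen-bond acceptors or net charge, is enough for a modest step beyond the scatter, and nothing available explains it.

With only methyl and fluoro shown at this place, it remains open how a chlorine, a methoxy group or a plain hydrogen there would read. On these data alone, it is also open whether the same exchange would give a similar step on the hydroxy compound.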